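Hydroxamate chain length on the shared core in breast-cancer cells

The source may report more compounds than this note shows. Statements on the series, on what has been measured and on what is new or still open speak of the compounds shown alone.

Measured so far:
compound 1 `Nc1ncnc2c1c(-c1cnc3[nH]ccc3c1)nn2CCCC(=O)NO` — > 150000 nM
compound 2 `Nc1nc2cc(-c3nn(CCCCCC(=O)NO)c4ncnc(N)c34)ccc2o1` — 19000 nM
compound 3 `Nc1ncnc2c1c(-c1cnc3[nH]ccc3c1)nn2CCCCCCC(=O)NO` — 37700 nM

The read-out is a functional assay on MDA-MB-231 cells (Homo sapiens) for inhibition, read by MTT assay, with a stated time of 72 h; a lower number here means a stronger inhibitor, a higher number a weaker inhibitor. Compound 1 gives only a limit in this assay, (the limit of > 150000 nM in this assay, at which 1 of the 3 values shown sits), and no number. Compound 2 and compound 3 are the two compounds with numbers, and in this assay compound 2 gives 19000 nM while compound 3 gives 37700 nM; the two lie within the scatter of one another, so no order between them is claimed.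

Among the measured compounds shown here, one step bears on the chain: an at least 3.9-fold lower number from compound 1 to compound 3 (0.59 log units; beyond the scatter). The longer chain thus gives the lower number, at least modestly.

Compound 4 `Nc1nc2cc(-c3nn(CCCCC(=O)NO)c4ncnc(N)c34)ccc2o1` is not yet measured. It differs from compound 2 by hydroxycarbamoyl in place of (hydroxycarbamoyl)methyl on a saturated chain carbon, four bonds along the chain from an aromatic nitrogen. This is the same kind of change as from compound 1 to compound 3, but cut in the other direction and by a single chain carbon rather than three. For the measured compounds named here, since shortening the chain went with a higher number in the one step measured, a modest rise in this assay is expected for compound 4, though a single-carbon change may well stay within the scatter.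

The expected value for compound 4 in this assay is 35000 nM, with a range from 15000 nM to 90000 nM. The step this implies is expected to be a 1.8-fold higher number from compound 2 to compound 4 (0.27 log units; within the scatter), a small weakening.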

Compound 4, half-maximal inhibitory concentration: 21200 nM
Estimate against measurement, compound 4: 1.7-fold (0.22 log units) above; low and high end bracket the measured number.
By their numbers in this assay, from the lowest: compounds 2, 4 and 3 (each within the scatter of the next). At a limit, above all of these: compound 1.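

In this assay, hydroxycarbamoyl in place of (hydroxycarbamoyl)methyl on a saturated chain carbon, four bonds along the chain from an aromatic nitrogen, gives a 1.1-fold higher number from compound 2 to compound 4 (0.05 log units; within the scatter), so this single-carbon change does not separate the two compounds. Among the compounds shown here, the only chain step available before this one, an at least 3.9-fold lower number from compound 1 to compound 3 (0.59 log units; beyond the scatter), belongs to a larger change in chain length on a different core, so the link between chain length and the number does not extend to this smaller change on the core of compound 2; compound 2 and compound 4 are the pair that goes against any general reading of that kind. No measured property shown here bears on this result.

Open, from the compounds shown here alone, is whether a longer chain, such as one carrying 4-(hydroxycarbamoyl)butyl at this position, or a still shorter chain on the core of compound 2 would give a step beyond the scatter in this assay. Also open, going by these compounds, is how a carboxylic acid or a primary amide in place of hydroxycarbamoyl would read on the chains of compound 2 and compound 4.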